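An isopropyl amide in place of a chlorophenyl amide

The compounds below may be only part of what the source reports. "The series", "measured", "known", "first", "only" and "open" are said of these compounds alone.

Of the compounds shown here, three sharing one core have been tested in a functional assay on HepG2 cells (Homo sapiens) for antiproliferative activity, read by CCK-8 assay, with a stated time of 48 h; on this read-out higher numbers stand for weaker inhibition and lower numbers for stronger inhibition. Compound 1 `COc1ccc(NC(=O)c2cc(Oc3ccc(/C=C/c4ccccn4)cc3)ccn2)cc1` gives 30000 nM. Compound 2 `O=C(Nc1ccc(Cl)cc1)c1cc(Oc2ccc(/C=C/c3ccccn3)cc2)ccn1` gives 31300 nM, and compound 3 `COc1ccc(CNC(=O)c2cc(Oc3ccc(/C=C/c4ccccn4)cc3)ccn2)cc1` gives 26000 nM. Compound 2 stands together with the other two rather than apart from them: the step of a 1.0-fold higher number from compound 1 to compound 2 (0.02 log units; within the scatter) and the step of a 1.2-fold lower number from compound 2 to compound 3 (0.08 log units; within the scatter) both sit inside the scatter, so the three numbers cannot be told apart. Compound 4 `CC(C)NC(=O)c1cc(Oc2ccc(/C=C/c3ccccn3)cc2)ccn1` has not yet been measured. It differs from compound 2 in one place: isopropyl in place of 4-chlorophenyl on an amide-type nitrogen. Going by the values given here, two measured steps bear on a change on the amide-type nitrogen, a 1.2-fold lower number from compound 1 to compound 3 (0.06 log units; within the scatter) and a 1.2-fold lower number from compound 2 to compound 3 (0.08 log units; within the scatter), and neither moved the number beyond the scatter. On that basis no shift beyond the scatter is expected for compound 4 in this assay, which means an expected step of a 1.0-fold lower number from compound 2 to compound 4 (0.02 log units; within the scatter). Compound 4 is therefore estimated at 30000 nM, with a range from 14000 nM to 65000 nM.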

Compound 4, half-maximal inhibitory concentration: > 100000 nM
Compound 4 ended at the assay's limit; the forecaster's own chance of this, stated with the estimate: 15%; middle value at least 3.3-fold (0.52 log units) away from the limit.
By their numbers in this assay, from the lowest: compounds 3, 1 and 2 (each within the scatter of the next). At a limit, above all of these: compound 4.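

In this assay compound 4 stands at a limit of the assay, not at a number: the limit of > 100000 nM in this assay, at which 1 of the 4 values shown sits. Going by these compounds alone, the amide-type nitrogen is therefore not as indifferent to change as the earlier compounds suggested, since all three steps to isopropyl lie beyond the scatter: an at least 3.1-fold higher number from compound 2 to compound 4 (0.50 log units; beyond the scatter), an at least 3.3-fold higher number from compound 1 to compound 4 (0.52 log units; beyond the scatter) and an at least 3.8-fold higher number from compound 3 to compound 4 (0.58 log units; beyond the scatter). Among these four compounds, the three lower numbers all go with a group that carries an aromatic ring, and no compound goes against this, though the true size of each step stays unread.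

Isopropyl differs from 4-chlorophenyl both in lacking the ring and in its smaller count of heavy atoms, so the compounds shown cannot separate the two. Also open, on these data alone, is how a cyclohexyl group or a longer chain such as n-hexyl would behave on this nitrogen.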